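Phenyl versus benzyl on the nitrogen: working notes

The source may hold more compounds than are shown below. What is called first, only, known or untested is meant among the compounds shown, and "the series" means these compounds.

Measured in a functional assay on MCF7 cells (Homo sapiens) for inhibition, read by CCK-8 assay, with a stated time of 48 h (on this read-out lower numbers stand for stronger inhibition of growth and higher numbers for weaker inhibition of growth), so far
compound 1 `CN1CCN(c2ccc(Nc3ncc(Cl)c(Nc4ccccc4)n3)nc2)CC1` gives 51800 nM
compound 2 `COc1cccc(CNc2nc(Nc3ccc(N4CCN(C)CC4)cn3)ncc2Cl)c1` gives 19500 nM

Compound 2 holds the lower of the two numbers, and the gap to compound 1 lies beyond the scatter. Compound 3 `Cc1ccc(Nc2nc(Nc3ccc(N4CCN(C)CC4)cn3)ncc2Cl)cc1` comes from compound 2 by a single change 4-methylphenyl in place of 3-methoxybenzyl on a nitrogen on an aromatic ring in which 4-methylphenyl takes the place of 3-methoxybenzyl on a nitrogen on an aromatic ring. Among the compounds with values here, one measured step bears on this. Within the data shown here, since a 2.7-fold lower number from compound 1 to compound 2 (0.42 log units; beyond the scatter) came with 3-methoxybenzyl in place of phenyl at that same place, and the new change removes 3-methoxybenzyl again in favour of a phenyl ring carrying a methyl group, a modest step towards a higher number is expected in this assay rather than no step. Among the measured compounds shown here, no measured compound shows how 4-methylphenyl compares with phenyl, so the range stays wide. For compound 3 the estimated value is 40000 nM with an expected range from 17000 nM to 90000 nM as the working figures. That estimate means a 2.1-fold higher number from compound 2 to compound 3 (0.31 log units; beyond the scatter) as the expected step.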

Compound 3, concentration for 50% growth inhibition: 11400 nM
Estimate against measurement, compound 3: 3.5-fold (0.55 log units) above; measured number below the stated range.
By their numbers in this assay, from the lowest: compounds 3 and 2 (each within the scatter of the next); then compound 1.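

In this assay, the step from the benzyl type to a substituted phenyl at this nitrogen, a 1.7-fold lower number from compound 2 to compound 3 (0.23 log units; within the scatter), leaves 3-methoxybenzyl and 4-methylphenyl indistinguishable, so a benzyl group is not needed to reach this level in the series. The second new step, a 4.5-fold lower number from compound 1 to compound 3 (0.66 log units; beyond the scatter), shows that methyl in place of hydrogen on an aromatic carbon of the phenyl group is enough for a change beyond the scatter, so the lower number seen with 3-methoxybenzyl is not confined to benzyl groups among these compounds. No supporting data accompany these numbers, and neither step can be assigned an explanation.

Still open, from the compounds shown here alone, is how a plain benzyl compares with 3-methoxybenzyl on this nitrogen, and how 3-methoxyphenyl compares with 4-methylphenyl, so the contributions of the ring substituent and the extra carbon remain unseparated. Also open, going by these compounds, is whether an amine, a carboxylic acid or a longer chain such as ethyl in place of the methyl of compound 3 would keep the number in this range.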